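Swapping Methyl for Methoxy on Compound 1

The source may report more compounds than this note shows. Statements on the series, on what has been measured and on what is new or still open speak of the compounds shown alone.

Compound 1 `Cc1cc(C)cc(C(=O)N(CCC(=O)NCc2ccccc2)Cc2ccc(C(=O)NO)cc2)c1` gives 1390 nM
Compound 2 `Cc1ccc(CNC(=O)CCN(Cc2ccc(C(=O)NO)cc2)C(=O)c2ccc(N(C)C)cc2)cc1` gives 260 nM

In a functional assay on IMR-32 cells (Homo sapiens) for antiproliferative activity, with a stated time of 72 h (on this read-out lower numbers stand for stronger inhibition and higher numbers for weaker inhibition), compound 1 stands highest at 1390 nM and is the weaker of the two, with compound 2 lower, beyond the scatter. Compound 3 `COc1cc(OC)cc(C(=O)N(CCC(=O)NCc2ccccc2)Cc2ccc(C(=O)NO)cc2)c1` carries 3,5-dimethoxyphenyl in place of 3,5-dimethylphenyl on a carbonyl carbon. Within the data shown here, no measured pair shows this change, so the expectation in this assay stays close to compound 1 at 1390 nM with a small drop, none beyond the scatter. The estimated change is a 1.5-fold lower number from compound 1 to compound 3 (0.19 log units; within the scatter) and it points downward. Compound 3 is expected at 900 nM, within an estimated range of 350 nM to 2300 nM.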

Compound 3, half-maximal inhibitory concentration: 6040 nM
Compound 3: the middle estimate sits 6.7-fold (0.83 log units) below what was measured; the whole stated range lies below it.
By their numbers in this assay, from the lowest: compound 2; then compound 1; then compound 3.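

In this assay, 3,5-dimethoxyphenyl in place of 3,5-dimethylphenyl on a carbonyl carbon gives a 4.3-fold higher number from compound 1 to compound 3 (0.64 log units; beyond the scatter) and so means weaker inhibition. Among these compounds, the earlier compounds differed in more than one place, so this is the first direct reading of what a single change here does. No measurement on hand accounts for the loss. Still open, as far as these compounds go, is how 3,5-dichlorophenyl, or a phenyl carrying a single methoxy or an amine, would read on the same carbonyl carbon.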